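The source may hold more compounds than are shown below. What is called first, only, known or untested is meant among the compounds shown, and "the series" means these compounds.

Measured so far:
compound 1 `Cc1ccccc1-c1nnc(N(N)C(C)C)s1` with 54 mg/kg
compound 2 `CNN(C)c1nnc(-c2ccccc2C)s1` with 10 mg/kg

In a functional assay on the whole organism with Mus musculus as the target, in the maximal electroshock model, with a stated time of 1 h (a lower number here means that less compound is needed, a higher number that more compound is needed for the effect), compound 2 has the lower of the two numbers measured, and compound 1 sits clearly higher. Compound 3 `Cc1ccccc1-c1nnc(NN(C)C)s1` differs from compound 2 only at the group on the shared core: (dimethylamino)amino in place of methyl(methylamino)amino on an aromatic carbon. Among the measured compounds shown here, the one step known so far, a 5.4-fold lower number from compound 1 to compound 2 (0.73 log units; beyond the scatter), changed this same group and moved the number well beyond the scatter, so changes here are not trivial. The direction for compound 3 is uncertain. The number for compound 3 is expected to lie close to compound 2, a step of a 1.5-fold higher number from compound 2 to compound 3 (0.18 log units; within the scatter), giving an estimate of 15 mg/kg within 6 mg/kg to 40 mg/kg.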

Compound 3, dose for half-maximal effect: 60 mg/kg
Beside the measured number, compound 3's estimate is 4.0-fold (0.60 log units) below it, and the stated range ends below it.
By their numbers in this assay, from the lowest: compound 2; then compounds 1 and 3 (each within the scatter of the next).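

The groups methyl(methylamino)amino and (dimethylamino)amino hold the same atoms joined differently, yet the swap moves the number well beyond the scatter (a 6.0-fold higher number from compound 2 to compound 3 (0.78 log units; beyond the scatter)), so at this position the arrangement of the atoms matters, not only which atoms are present. By contrast, (dimethylamino)amino and amino(isopropyl)amino are not separated (a 1.1-fold higher number from compound 1 to compound 3 (0.05 log units; within the scatter)), leaving compound 2 alone at the low end of the three. Nothing available here explains this gap.

Still open, on these data alone, is whether a longer chain, such as an ethyl in place of either methyl in methyl(methylamino)amino, keeps the low number of compound 2. A simple amine at this position is equally untested by the compounds shown.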